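Thioether Chalcone Analogues Tested on DU-145 Cells

The source may hold more compounds than are shown below. What is called first, only, known or untested is meant among the compounds shown, and "the series" means these compounds.

Compound 1 `Nc1c(Br)cc(Br)cc1/C=C(\C(=O)c1ccc(Br)cc1)S(=O)(=O)c1ccc(Br)cc1`: 25000 nM
Compound 2 `O=C(/C(=C\c1ccc(I)cc1)Sc1ccc(Br)cc1)c1ccc(Br)cc1`: 1000 nM

In a functional assay on DU-145 cells (Homo sapiens) for inhibition, read by trypan blue exclusion, with a stated time of 96 h (a higher number here means a weaker inhibitor of growth, a lower number a stronger inhibitor of growth), compound 1 gives 25000 nM. In this assay compound 2 gives 1000 nM, the lowest of the two numbers, and its gap to compound 1 is beyond the scatter. Compound 3 `Nc1c(Br)cc(Br)cc1/C=C(/Sc1ccc(Br)cc1)C(=O)c1ccc(Br)cc1` is not yet measured; it differs from compound 2 by 2-amino-3,5-dibromophenyl in place of 4-iodophenyl on a double-bonded chain carbon bound to a double-bonded chain carbon. Among the measured compounds shown here, compound 1 carries the same entering group and gives a high number, but it differs from compound 3 elsewhere too, so no step is known. The step expected here is a 3.0-fold higher number from compound 2 to compound 3 (0.48 log units; beyond the scatter), a moderate rise. Compound 3 is estimated at 3000 nM, within 500 nM to 20000 nM.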

Compound 3, concentration for 50% growth inhibition: > 100000 nM
Compound 3: no number, only a limit (the forecaster's own chance of this, stated with the estimate: 10%); middle value at least 33-fold (1.52 log units) away from the limit.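

In this assay compound 3 stands only as a limit of the assay: the limit of > 100000 nM in this assay, at which 1 of the 3 values shown sits. Putting 2-amino-3,5-dibromophenyl in place of 4-iodophenyl on a double-bonded chain carbon bound to a double-bonded chain carbon gives an at least 100-fold higher number from compound 2 to compound 3 (2.00 log units; beyond the scatter), a large loss at this position. Among the compounds shown here, with that group present, (4-bromophenyl)sulfanyl in place of (4-bromophenyl)sulfonyl gives an at least 4.0-fold higher number from compound 1 to compound 3 (0.60 log units; beyond the scatter), so here the sulfonyl compound is the one with a measured number.

The compounds shown do not separate the amine of the entering group from its two bromine atoms. Going by these compounds, how a plain phenyl or a methoxyphenyl would read at this position also remains open.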